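A few compounds are considered here, and "the series" means these few. Any claim that something is new, unique, unknown or untested is made for them only; others in the source may bear on it.

Within the data shown here, in an ADME assay on the whole organism with Oryza sativa as the target, tested at 1 uM (a higher number here means a weaker effect of the compound at the concentration tested, a lower number a stronger effect), compound 2 `CC(=O)c1ccc(NC(=O)N[C@@H](C)c2ccccc2)cc1` gives 99%, and compound 1 `C[C@H](NC(=O)Nc1ccc(C(F)(F)F)cc1)c1ccccc1` gives 94%; the two values sit within the scatter of each other, the only step measured so far being a number 5 percentage points higher from compound 1 to compound 2 (within the scatter). Compound 3 `C[C@H](NC(=O)Nc1ccc(I)cc1)c1ccccc1` differs from compound 2 by iodo in place of acetyl on an aromatic carbon. Among the measured compounds shown here, the single measured step exchanged one para substituent for another without moving this assay beyond its scatter, so a change at the same place is expected to leave the read-out much where it is. Compound 3 is therefore expected to give 95%, within a range from 86% to 100%. The expected step amounts to a number 4 percentage points lower from compound 2 to compound 3 (within the scatter).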

Compound 3, a percentage reported as activity, at one concentration (the size of the read-out at that concentration, not a potency): 97%
Compound 3: the middle estimate sits 2 percentage points below what was measured; low and high end bracket the measured number.
By their numbers in this assay, from the lowest: compounds 1, 3 and 2 (each within the scatter of the next).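

At this position of the shared core, this assay now compares three groups. Iodo in place of acetyl gives a number 2 percentage points lower from compound 2 to compound 3 (within the scatter) and iodo in place of trifluoromethyl gives a number 3 percentage points higher from compound 1 to compound 3 (within the scatter), so a single iodine atom reads like either larger group. None of these three exchanges at this aromatic carbon has moved the read-out beyond the scatter.

As far as these compounds go, it remains open whether an amine or a carboxylic acid at this place would do so. No evidence at hand explains why these three groups read alike.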